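Halogen pattern on the anilino group: compound 4 expected

The source may hold more compounds than are shown below. What is called first, only, known or untested is meant among the compounds shown, and "the series" means these compounds.

Three compounds share one core and differ only in the aryl group on the nitrogen on an aromatic ring. Compound 1 `CN1CCN(CCCOc2cccc3nc(Nc4ccc(Cl)c(C(F)(F)F)c4)ccc23)CC1` gives 1600 nM in a functional assay on MDA-MB-468 cells (Homo sapiens) for inhibition, read by sulforhodamine B assay, with a stated time of 48 h; on this read-out lower numbers stand for stronger inhibition of growth and higher numbers for weaker inhibition of growth. Compound 2 `CN1CCN(CCCOc2cccc3nc(Nc4ccc(Cl)c(F)c4)ccc23)CC1` gives 1720 nM in this assay, and compound 3 `CN1CCN(CCCOc2cccc3nc(Nc4ccc(F)c(F)c4)ccc23)CC1` gives 2110 nM in this assay. Compound 3 carries the highest of the three numbers, yet both steps leading to it sit within the scatter: a 1.3-fold higher number from compound 1 to compound 3 (0.12 log units; within the scatter) and a 1.2-fold higher number from compound 2 to compound 3 (0.09 log units; within the scatter). The step of a 1.1-fold higher number from compound 1 to compound 2 (0.03 log units; within the scatter) is likewise within the scatter, so the three halogen patterns measured so far are not separated by this read-out.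

Compound 4 `CN1CCN(CCCOc2cccc3nc(Nc4cc(Cl)cc(Cl)c4)ccc23)CC1` is not yet measured. It differs from compound 3 by 3,5-dichlorophenyl in place of 3,4-difluorophenyl on a nitrogen on an aromatic ring. Among the compounds with values here, two measured steps bear on this change: fluoro against chloro on an aromatic carbon, a 1.2-fold higher number from compound 2 to compound 3 (0.09 log units; within the scatter), and an exchange of the whole halogenated aryl group, a 1.3-fold higher number from compound 1 to compound 3 (0.12 log units; within the scatter); neither moved the number beyond the scatter. Within the data shown here, no measured compound carries a 3,5-dichlorophenyl, so that pattern is untested. The expected step in this assay is therefore a 1.1-fold lower number from compound 3 to compound 4 (0.05 log units; within the scatter), none beyond the scatter, with the range kept wide for the untested pattern. Compound 4 is estimated at 1900 nM, within 900 nM to 4000 nM.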

Compound 4, concentration for 50% growth inhibition: 1690 nM
The estimate for compound 4 lay 1.1-fold (0.05 log units) above the measured number; low and high end bracket the measured number.
By their numbers in this assay, from the lowest: compounds 1, 4, 2 and 3 (each within the scatter of the next).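

Exchanging 3,4-difluorophenyl for 3,5-dichlorophenyl on a nitrogen on an aromatic ring gives a 1.2-fold lower number from compound 3 to compound 4 (0.10 log units; within the scatter) in this assay, so a different halogen pattern, and not only the exchange of one halogen for another, stays within the scatter at this position. The comparisons with the other two aryl groups agree, with a 1.0-fold lower number from compound 2 to compound 4 (0.01 log units; within the scatter) and a 1.1-fold higher number from compound 1 to compound 4 (0.02 log units; within the scatter), so this read-out separates none of the four halogenated phenyl groups, and no compound shown goes against that. Nothing shown accounts for this flat picture.

As far as these compounds go, all four compounds carry only halogen or trifluoromethyl groups on the phenyl ring, so it remains open whether an amine, a carboxylic acid or a methoxy group there would leave the number in the same range. From the compounds shown here alone, the chain on the oxygen of the shared core is the same throughout, so the effect of a longer chain, and whether a change there would move the number beyond the scatter where the aryl exchanges did not, also remains open.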